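This account rests on a few compounds, and the source may have more. Where it says the series, first, only, none or still open, it means among the compounds named here.

Working notes on the series. Compound 1 `COCc1ncc2cnnc(NCCN(C)C)n12` gives only a limit in a functional assay for inhibition, with Homo sapiens as the target (on this read-out higher numbers stand for weaker inhibition and lower numbers for stronger inhibition), > 48000 nM. Compound 3 `CN(C)CCNc1nncc2cncn12` likewise returns a limit in this assay, > 48000 nM. Among the measured compounds shown here, compound 2 `Cc1nc(C(C)(C)C)n2c(O)nncc12` is the sole member with a number: in this assay compound 2 gives 31000 nM. For the measured compounds named here, the one single-point step available, a step that the two limits leave unreadable from compound 1 to compound 3, has limits at both ends and so cannot be read; it also concerns a different group from the one changed here. Compound 1 thus stands at the limit of > 48000 nM in this assay, at which 2 of the 3 values shown sit, not at a number.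

The unmeasured compound 4 `COCc1ncc2cnnc(SC)n12` differs from compound 1 in one place: methylsulfanyl in place of (2-(dimethylamino)ethyl)amino on an aromatic carbon. Going by the values given here, no measured step bears on this change, and the compound 2 value is a lone number with no single-point partner. The expected step that the limit leaves unreadable from compound 1 to compound 4 is therefore no change beyond the scatter, read from a limit. Compound 4 is expected in this assay near 50000 nM, within 20000 nM to 150000 nM, most likely reported as a limit again.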

Compound 4, half-maximal inhibitory concentration: > 48000 nM
Compound 4 ended at the assay's limit; the forecaster's own chance of this, stated with the estimate: 70%; the middle value lies beyond the limit too.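

Compound 1 and compound 4 both end at a limit in this assay, so the step between them cannot be read: the limit of > 48000 nM in this assay, at which 3 of the 4 values shown sit.

Still open is whether methylsulfanyl or (2-(dimethylamino)ethyl)amino on the shared core makes any difference to inhibition; of the compounds shown, only compound 2 gives a number, 31000 nM.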